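This account rests on a few compounds, and the source may have more. Where it says the series, first, only, none or still open, it means among the compounds named here.

Compound 2 `COc1ccc(C(=O)c2cnc(Nc3cccc(C#N)c3)s2)cc1` gives 2230 nM in an assay for inhibition of Neuropeptide Y receptor type 5 (Mus musculus) (a lower number here means a stronger inhibitor, a higher number a weaker inhibitor), the highest of the three numbers recorded. Compound 1 `COc1cccc(Nc2ncc(C(=O)c3ccccc3F)s2)c1` gives 1000 nM in this assay, and compound 3 `N#Cc1cccc(Nc2ncc(C(=O)c3ccccc3C(F)(F)F)s2)c1` gives 20 nM. Compound 4 `Cc1cc(C(=O)c2cnc(Nc3cccc(C#N)c3)s2)c(C)s1` differs from compound 2 by 2,5-dimethylthiophen-3-yl in place of 4-methoxyphenyl on a carbonyl carbon. For the measured compounds named here, no measured pair isolates this change, so its size cannot be read off directly; compounds 1 and 3 show that other ketone aryl groups sit well below compound 2, which suggests room for a lower number. The step from compound 2 to compound 4 is expected to be a 6.4-fold lower number from compound 2 to compound 4 (0.80 log units; beyond the scatter), downward. Compound 4 is therefore estimated at 350 nM in this assay, in a range from 70 nM to 1800 nM.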

Compound 4, half-maximal inhibitory concentration: 14 nM
Compound 4: middle estimate off by 25-fold (1.40 log units), on the high side; the measured number lies below the stated range.
By their numbers in this assay, from the lowest: compounds 4 and 3 (each within the scatter of the next); then compound 1; then compound 2.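

Putting 2,5-dimethylthiophen-3-yl in place of 4-methoxyphenyl on a carbonyl carbon gives a 160-fold lower number from compound 2 to compound 4 (2.20 log units; beyond the scatter) in this assay, so a change at this one position can be large. A five-membered aromatic ring is tolerated here: compound 4 gives 14 nM and compound 3 gives 20 nM, values within the scatter of each other. Nothing available explains the size of this step. The compounds shown do not separate the two methyl groups from the ring that carries them. On these data alone, it remains open whether an unsubstituted thiophen-3-yl or a pyridyl ring would give a similar number.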